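A few compounds are considered here, and "the series" means these few. Any claim that something is new, unique, unknown or untested is made for them only; others in the source may bear on it.

Measured in this assay:
compound 1 `C=C1CCCC(C)(C)C1CC[C@]1(C)CC[C@@H]([C@@H](C)C(=O)O)OO1` — > 10000 nM
compound 2 `C=C1CCC[C@H]2[C@](C)(CC[C@]3(C)CC[C@@H]([C@@H](C)C(=O)O)OO3)[C@@H](C)CC[C@]12C` — 1160 nM
compound 3 `C=C1CCCC(C)(C)C1(O)CC/C(C)=C/CC[C@]1(C)CC[C@@H]([C@@H](C)C(=O)OC)OO1` — > 17500 nM

All three were run in a functional assay on SW-620 cells (Homo sapiens) for inhibition; on this read-out higher numbers stand for weaker inhibition of growth and lower numbers for stronger inhibition of growth. For compound 1 the entry > 10000 nM is a limit of the assay and not a number (the limit of > 10000 nM in this assay, at which 1 of the 3 values shown sits). For compound 3 the entry > 17500 nM is likewise a limit and not a number (the limit of > 17500 nM in this assay, at which 1 of the 3 values shown sits). For the measured compounds named here, compound 2 gives 1160 nM in this assay, and this is the only number among the three. Going by the values given here, no pair of measured compounds differs in a single place, so no measured step is available in this assay.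

Compound 4 `C=C1CCC[C@H]2[C@](C)(CC[C@]3(C)CC[C@H]([C@@H](C)C(=O)O)OO3)[C@@H](C)CC[C@]12C` has not yet been measured in this assay. Set against compound 2 the change is the two compounds have the same atoms and bonds and differ only in configuration as drawn: 1 of 7 stereo elements differ; a stereocentre at a saturated ring carbon is drawn S in compound 2 and R in compound 4. Among the compounds with values here, the series gives no measured step of this kind to lean on. The expectation is that the step from compound 2 to compound 4 in this assay goes toward weaker inhibition of growth, by an amount beyond the usual scatter but not large; a step within the scatter, or one toward stronger inhibition, cannot be ruled out. The step expected is a 2.6-fold higher number from compound 2 to compound 4 (0.41 log units; beyond the scatter). Compound 4 is estimated at 3000 nM in this assay, with a range from 800 nM to 15000 nM.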

Compound 4, concentration for 50% growth inhibition: 1570 nM
The estimate for compound 4 lay 1.9-fold (0.28 log units) above the measured number; measured number inside the range.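

In this assay, for the compounds shown here, the change at the one stereocentre at a saturated ring carbon, drawn S in compound 2 and R in compound 4, gives the first measured step (a 1.4-fold higher number from compound 2 to compound 4 (0.13 log units; within the scatter)). This step lies within the scatter, so in this pair the drawn configuration at this stereocentre does not separate the two compounds on growth inhibition, something no earlier comparison could show. The pair reads this one change in isolation, with nothing entering or leaving: the fact that compounds 2 and 4 differ only in the configuration as drawn.

Compound 1 gives > 10000 nM, which is a limit and not a number, so whether the same change would register on a compound with that value stays unresolved. On these data alone, it also remains open whether the result at this stereocentre would hold with an amide or a primary amine in place of the carboxylic acid, and whether changing any of the other stereo elements would give a step beyond the scatter.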